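The source may hold more compounds than are shown below. What is called first, only, known or untested is meant among the compounds shown, and "the series" means these compounds.

In a physicochemical assay for solubility, in phosphate buffer, with a stated time of 24 h, at pH 7.4, tested at 100 uM (on this read-out lower numbers stand for lower solubility and higher numbers for higher solubility), compound 3 `O=C(NCc1ccc(S(=O)(=O)C2CCCOC2)cc1)N1Cc2ccncc2C1` gives 208000 nM and sits within the scatter of compound 1 `CC(C)n1cc(S(=O)(=O)c2ccc(CNC(=O)N3Cc4ccncc4C3)cc2)cn1` which gives 192000 nM in the same read-out. Compound 2 `O=C(NCc1ccc(S(=O)(=O)C2CCC(F)(F)CC2)cc1)N1Cc2ccncc2C1` gives 35000 nM and stands lower than both. Compound 4 `O=C(NCc1ccc(S(=O)(=O)N2CCC[C@@H](O)C2)cc1)N1Cc2ccncc2C1` keeps the shared core and brings 3-hydroxypiperidin-1-yl in place of oxan-3-yl on a sulfonyl sulfur, a change that counts up as follows (3-hydroxypiperidin-1-yl in place of oxan-3-yl on a sulfonyl sulfur). Among the compounds with values here, two measured steps bear on this place. With oxan-3-yl in place of 4,4-difluorocyclohexyl the data show a 5.9-fold higher number from compound 2 to compound 3 (0.77 log units; beyond the scatter) and so a modest rise, whereas with oxan-3-yl in place of 1-isopropyl-1H-pyrazol-4-yl they show a 1.1-fold higher number from compound 1 to compound 3 (0.03 log units; within the scatter) and no change beyond the scatter. Within the data shown here, no measured compound carries a hydrogen-bond donor in this group, so neither step is a direct guide. The entering group, like the oxan-3-yl of compound 3 at 208000 nM on this scale, is one six-membered non-aromatic ring with 1 hetero atom, so the expectation in this assay is no step beyond the scatter in either direction. The expected size is a 1.2-fold lower number from compound 3 to compound 4 (0.09 log units; within the scatter) by this estimate. Compound 4 is expected at 170000 nM with 80000 nM and 280000 nM as the estimated ends of its range.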

Compound 4, solubility: 216000 nM
Compound 4: middle estimate off by 1.3-fold (0.10 log units), on the low side; the measured number falls inside the stated range.
By their numbers in this assay, from the lowest: compound 2; then compounds 1, 3 and 4 (each within the scatter of the next).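

Among the compounds shown, only compound 4 carries a hydrogen-bond donor in the group on the sulfonyl sulfur, and it is also the only one with a defined stereocentre in that group. In this assay, within the data shown here, putting 3-hydroxypiperidin-1-yl in place of oxan-3-yl gives a result (a 1.0-fold higher number from compound 3 to compound 4 (0.02 log units; within the scatter)) that lies within the scatter, so this donor-bearing ring does not separate compound 4 from the oxan-3-yl compound, and the comparison with the 1-isopropyl-1H-pyrazol-4-yl group (a 1.1-fold higher number from compound 1 to compound 4 (0.05 log units; within the scatter)) also lies within the scatter, whereas the step from the 4,4-difluorocyclohexyl group (a 6.2-fold higher number from compound 2 to compound 4 (0.79 log units; beyond the scatter)) lies beyond it, leaving compound 2 as the one compound set apart from the other three. Nothing measured here gives a reason for this grouping.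

Still open, going by these compounds, is whether an open-chain dimethylamino group or a ring bearing a carboxylic acid on the sulfonyl sulfur would stand with compound 2 or with the other three. Equally open, on these data alone, is how piperidin-1-yl without its hydroxy group, or the mirror-image form of 3-hydroxypiperidin-1-yl, would compare with compound 4.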